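From 4-chlorophenyl to 3,4-difluorophenyl on compound 2

A few compounds are considered here, and "the series" means these few. Any claim that something is new, unique, unknown or untested is made for them only; others in the source may bear on it.

In an ADME assay on the whole organism (Rattus norvegicus, strain Sprague-Dawley) for pharmacokinetics, using cassette dosing, at a dose of 0.5 mg/kg by the intravenous route (on this read-out higher numbers stand for fast clearance and lower numbers for slow clearance), compound 1 (`O=C(Nc1ccc2[nH]c(=O)oc2c1)C(=O)N1CCN(c2ccc(F)c(F)c2)CC1`) gives 4 mL/min/kg as its measured number. Compound 2 (`C[C@@H]1CN(c2ccc(Cl)cc2)CCN1C(=O)C(=O)Nc1ccc2[nH]c(=O)oc2c1`) gives 5.4 mL/min/kg and so stands within the usual scatter of compound 1. Compound 3 (`C[C@H]1CN(c2ccc(Cl)cc2)CCN1C(=O)C(=O)Nc1ccc2[nH]c(=O)oc2c1`) stands as "not determined" (no result reported) and adds no number. Compound 4 (`C[C@@H]1CN(c2ccc(F)c(F)c2)CCN1C(=O)C(=O)Nc1ccc2[nH]c(=O)oc2c1`) keeps the methyl group of compound 2, with 3,4-difluorophenyl in place of 4-chlorophenyl on an amine nitrogen in a ring. Compound 1 already carries 3,4-difluorophenyl, and its 4 mL/min/kg lies within the scatter of compound 2, so no step beyond the scatter is expected in this assay here. The expected change is small (a 1.1-fold lower number from compound 2 to compound 4 (0.03 log units; within the scatter)) and stays within that scatter. For compound 4 the estimated clearance is 5 mL/min/kg with an expected range from 2.5 mL/min/kg to 10 mL/min/kg around it.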

Compound 4, clearance: 5.6 mL/min/kg
For compound 4 the middle estimate is 1.1-fold (0.05 log units) below the measured one; low and high end bracket the measured number.
By their numbers in this assay, from the lowest: compounds 1, 2 and 4 (each within the scatter of the next).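

In this assay, the change from 4-chlorophenyl to 3,4-difluorophenyl can now be read directly with the methyl group kept, and it gives a 1.0-fold higher number from compound 2 to compound 4 (0.02 log units; within the scatter) as its step. Among the compounds shown here, the methyl group on the saturated ring carbon can also be read alone for the first time, with a 1.4-fold higher number from compound 1 to compound 4 (0.15 log units; within the scatter) as its step. Neither change moves clearance beyond the scatter, and nothing available explains this result.

On these data alone, whether an ethyl group in place of that methyl would leave clearance equally unmoved stays open. So does the effect of an amine or a carboxylic acid on the phenyl ring.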